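The compounds below may be only part of what the source reports. "The series", "measured", "known", "first", "only" and "open" are said of these compounds alone.

Measured so far:
- compound 1 `CCCCCCOc1cc(C(C)(C)C)ccc1C/N=C(\S)NCc1ccc(NS(C)(=O)=O)cc1`, in a functional assay for inhibition of Vanilloid receptor (Rattus norvegicus) (on this read-out higher numbers stand for weaker inhibition and lower numbers for stronger inhibition), compound 1 gives 150 nM
- compound 2 `CC(C)Oc1cc(C(C)(C)C)ccc1C/N=C(\S)NCc1ccc(NS(C)(=O)=O)cc1`, compound 2 gives 350 nM
- compound 3 `CC(C)(C)COc1cc(C(C)(C)C)ccc1C/N=C(\S)NCc1ccc(NS(C)(=O)=O)cc1`, compound 3 gives 60 nM

Compound 1 sits second highest of the three; compound 2 is nearest, compound 3 furthest. Compound 4 `CC(C)(C)C(=O)Oc1cc(C(C)(C)C)ccc1C/N=C(\S)NCc1ccc(NS(C)(=O)=O)cc1` is unmeasured; it differs from compound 1 by (tert-butyl)carbonyl in place of hexyl on an oxygen on an aromatic ring. The steps that touch the same oxygen are a 2.3-fold higher number from compound 1 to compound 2 (0.37 log units; beyond the scatter) and a 2.5-fold lower number from compound 1 to compound 3 (0.40 log units; beyond the scatter), both modest and in opposite directions. For the measured compounds named here, no measured step introduces a carbonyl at this place, so those steps bear only loosely on compound 4. The expected step of a 1.3-fold higher number from compound 1 to compound 4 (0.12 log units; within the scatter) is therefore small, without a firm direction. Compound 4 is estimated at 200 nM, expected between 60 nM and 700 nM.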

Compound 4, half-maximal inhibitory concentration: 220 nM
For compound 4 the middle estimate is 1.1-fold (0.04 log units) below the measured one; low and high end bracket the measured number.
By their numbers in this assay, from the lowest: compound 3; then compounds 1, 4 and 2 (each within the scatter of the next, the first and the last beyond it).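

With a 1.5-fold higher number from compound 1 to compound 4 (0.17 log units; within the scatter) and a 1.6-fold lower number from compound 2 to compound 4 (0.20 log units; within the scatter) the (tert-butyl)carbonyl group on this oxygen is not separated from hexyl or isopropyl, so a carbonyl at this place still gives a number in the same range. Neopentyl carries the same tert-butyl end without the carbonyl yet stays apart, as a 3.7-fold higher number from compound 3 to compound 4 (0.56 log units; beyond the scatter) shows, so the tert-butyl end alone does not set the number. Nothing available explains this gap.

Open, on these data alone, is what acetyl, a carbamate or a free hydroxyl on this oxygen would give. Also open, as far as these compounds go, is whether a longer branched chain would match or pass neopentyl.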